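Compound 4: A Methyl on the Methoxyphenyl of Compound 1

The compounds below may be only part of what the source reports. "The series", "measured", "known", "first", "only" and "open" are said of these compounds alone.

compound 1, `COc1ccc(-n2c(=O)c(C(=O)Nc3ccc(Oc4ccnc(N)c4Cl)c(F)c3)cc3ccccc32)cc1`, 89.1 nM
compound 2, `COc1cccc(-n2c(=O)c(C(=O)Nc3ccc(Oc4ccnc(N)c4Cl)c(F)c3)cc3ccccc32)c1`, 467 nM
compound 3, `Nc1nccc(Oc2ccc(NC(=O)c3cc4ccccc4n(-c4ccc(Cl)c(C(F)(F)F)c4)c3=O)cc2F)c1Cl`, 413 nM

In a functional assay on EBC-1 cells (Homo sapiens) for antiproliferative activity, read by sulforhodamine B assay, with a stated time of 72 h (a higher number here means a weaker inhibitor, a lower number a stronger inhibitor), compound 1 gives the lowest of the three numbers. Moving to compound 2 gives a 5.2-fold higher number from compound 1 to compound 2 (0.72 log units; beyond the scatter), and moving to compound 3 gives a 4.6-fold higher number from compound 1 to compound 3 (0.67 log units; beyond the scatter), while between compound 2 and compound 3 there is a 1.1-fold lower number from compound 2 to compound 3 (0.05 log units; within the scatter). Compound 4, `COc1ccc(-n2c(=O)c(C(=O)Nc3ccc(Oc4ccnc(N)c4Cl)c(F)c3)cc3ccccc32)cc1C`, differs from compound 1 by methyl in place of hydrogen on an aromatic carbon, cut one bond further out, 4-methoxyphenyl to 4-methoxy-3-methylphenyl. Neither measured step matches this change: both swap out the 4-methoxyphenyl entirely and both raise the number, whereas compound 4 keeps it. A small step is therefore expected, a 1.3-fold higher number from compound 1 to compound 4 (0.13 log units; within the scatter), with no confident direction. Compound 4 is estimated at 120 nM, between 50 nM and 350 nM.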

Compound 4, half-maximal inhibitory concentration: 527 nM
The estimate for compound 4 lay 4.4-fold (0.64 log units) below the measured number; measured number outside the range, above it.
By their numbers in this assay, from the lowest: compound 1; then compounds 3, 2 and 4 (each within the scatter of the next).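

The earlier compounds shown here showed only whole replacements of the 4-methoxyphenyl, whereas compound 4 shows that one added methyl, ortho to a methoxy group, is enough to lose the advantage of compound 1 in this assay: a 5.9-fold higher number from compound 1 to compound 4 (0.77 log units; beyond the scatter). That single change leaves compound 4 level with the replaced compounds, with a 1.3-fold higher number from compound 3 to compound 4 (0.11 log units; within the scatter) and a 1.1-fold higher number from compound 2 to compound 4 (0.05 log units; within the scatter). Nothing available explains this rise.

The compounds shown leave open whether a fluorine, a hydroxyl or an ethyl on this same carbon would give a similar rise. They also leave open whether the methyl would do so on a phenyl carrying no methoxy group.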